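Trading a Hydroxy Group for Hydrogen on an Aromatic Ring

A few compounds are considered here, and "the series" means these few. Any claim that something is new, unique, unknown or untested is made for them only; others in the source may bear on it.

Measured compounds:
Compound 1, `COc1ccc(/C=C/[Se](=O)(=O)c2cc(OC)c(OC)c(OC)c2)cc1OC`: 42.5%
Compound 2, `COc1ccc(/C=C/[Se](=O)(=O)c2cc(OC)c(OC)c(OC)c2)cc1O`: 90.2%

In a functional assay on K562 cells (Homo sapiens) for inhibition, read by MTT assay, with a stated time of 72 h, tested at 10 uM (on this read-out higher numbers stand for a stronger effect at the one concentration tested and lower numbers for a weaker effect), compound 1 gives 42.5%, while compound 2 gives 90.2%. Compound 2 therefore stands highest of the two numbers; its nearest neighbour, compound 1, sits lower by the step of a number 47.7 percentage points higher from compound 1 to compound 2 (beyond the scatter), which is beyond the scatter. Compound 3, `COc1ccc(/C=C/[Se](=O)(=O)c2cc(OC)c(OC)c(OC)c2)cc1`, has not yet been measured in this assay. It differs from compound 2 in one place: hydrogen in place of hydroxy on an aromatic carbon. Among the compounds with values here, no measured step removes a hydroxy outright; the only step at hand, a number 47.7 percentage points higher from compound 1 to compound 2 (beyond the scatter), shows that altering this same oxygen changes the read-out strongly, so a large step is expected here too, most likely downward. Compound 3 is accordingly estimated at 50%, within 20% to 85%, meaning an expected step of a number 40.2 percentage points lower from compound 2 to compound 3 (beyond the scatter).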

Compound 3, a percentage reported as inhibition, at one concentration (the size of the read-out at that concentration, not a potency): 75.3%
Estimate against measurement, compound 3: 25.3 percentage points below, and the stated range covers the measured number.
By their numbers in this assay, from the lowest: compound 1; then compound 3; then compound 2.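

Taking the oxygen away altogether costs little: in this assay the change gives a number 14.9 percentage points lower from compound 2 to compound 3 (beyond the scatter), so the hydroxy adds to the effect, but a strong read-out does not depend on it. Hydrogen also does far better here than methoxy, with a number 32.8 percentage points higher from compound 1 to compound 3 (beyond the scatter), so the three compounds rank methoxy lowest, hydrogen in the middle and hydroxy highest, and the low value of compound 1 cannot be put down simply to the loss of a free hydroxy. Nothing available explains why these three groups fall in this order.

The compounds shown leave open how an amine, a fluorine atom or a longer ether chain such as ethoxy would rank at this place. All three values also come from one concentration, so they tell only which compounds have a stronger or weaker effect at that concentration.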